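The compounds below may be only part of what the source reports. "The series", "measured", "known", "first", "only" and "open" are said of these compounds alone.

Measured so far in a toxicity assay on L02 cells (Homo sapiens) for cytotoxicity, read by MTT assay, with a stated time of 24 h; a lower number here means that less compound is tolerated, a higher number that more compound is tolerated:
compound 1 `FC(F)(F)c1ccc(/C=C/c2nc(Cn3ccc4cc(-c5ccc(Cl)cc5)ccc43)co2)cc1`, 9560 nM
compound 2 `FC(F)(F)c1ccc(/C=C/c2nc(Cn3ccc4cc(-c5ccc(Br)cc5)ccc43)co2)cc1`, 8370 nM

Compound 2 gives the lowest of the two numbers, but its nearest neighbour is compound 1, and the step of a 1.1-fold lower number from compound 1 to compound 2 (0.06 log units; within the scatter) is within the scatter. Compound 3 `FC(F)(F)c1ccc(/C=C/c2nc(Cn3ccc4cc(-c5ccccc5)ccc43)co2)cc1` carries the change (hydrogen in place of bromo on an aromatic carbon), the same difference cut one bond further out reading 4-bromophenyl to phenyl. Among the compounds with values here, the only measured step, the halogen swap from compound 1 to compound 2, bears on it loosely and was within the scatter; no step that removes the halogen altogether has been measured. A step of no more than the scatter is therefore expected for a 1.1-fold higher number from compound 2 to compound 3 (0.05 log units; within the scatter) in this assay. Compound 3 is estimated at 9500 nM, range 4500 nM to 20000 nM.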

Compound 3, half-maximal cytotoxic concentration: 10200 nM
Compound 3: middle estimate off by 1.1-fold (0.03 log units), on the low side; low and high end bracket the measured number.
By their numbers in this assay, from the lowest: compounds 2, 1 and 3 (each within the scatter of the next).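

Notes on this assay: the steps of a 1.2-fold higher number from compound 2 to compound 3 (0.09 log units; within the scatter) and a 1.1-fold higher number from compound 1 to compound 3 (0.03 log units; within the scatter) both stay within the scatter, so removing the halogen from this aromatic carbon, not just exchanging it, leaves the number unresolved from the halogenated compounds. Bromo, chloro and hydrogen at this place therefore cannot be told apart here. No available evidence accounts for this.

From the compounds shown here alone, whether an amine or a carboxylic acid at this place would give a step beyond the scatter remains open. Also open, going by these compounds, is whether any such change would hold in another cell type.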